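Adding Nitro to Compound 2: An Expected Potency Shift

A few compounds are considered here, and "the series" means these few. Any claim that something is new, unique, unknown or untested is made for them only; others in the source may bear on it.

Of the compounds shown here, two have been tested in a functional assay on MCF7 cells (Homo sapiens) for antiproliferative activity, read by MTT assay, with a stated time of 24 h; on this read-out higher numbers stand for weaker inhibition and lower numbers for stronger inhibition. Compound 1 `O=[N+]([O-])c1ccc(S(=O)(=O)n2c(-c3cn(-c4ccccc4)nc3-c3ccc(F)cc3)nc3ccccc32)cc1` gives 1370 nM, while compound 2 `O=S(=O)(c1ccccc1)n1c(-c2cn(-c3ccccc3)nc2-c2ccc(C(F)(F)F)cc2)nc2ccccc21` gives 630 nM, the lower of the two numbers and beyond the scatter from compound 1. Compound 3 `O=[N+]([O-])c1ccc(S(=O)(=O)n2c(-c3cn(-c4ccccc4)nc3-c3ccc(C(F)(F)F)cc3)nc3ccccc32)cc1` is compound 2 with one change: nitro in place of hydrogen on an aromatic carbon. Compound 1 and compound 2 differ in more than one place, so their two values alone do not show what nitro in place of hydrogen does. The step of a 1.4-fold higher number from compound 2 to compound 3 (0.15 log units; within the scatter) is expected to be small, probably toward a weaker result, possibly none beyond the scatter. Compound 3 is estimated at 900 nM, within 400 nM to 2000 nM.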

Compound 3, half-maximal inhibitory concentration: 1130 nM
The estimate for compound 3 lay 1.3-fold (0.10 log units) below the measured number; the range from low to high includes it.
By their numbers in this assay, from the lowest: compounds 2, 3 and 1 (each within the scatter of the next, the first and the last beyond it).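

Compound 3 links compounds 1 and 2, which differ in more than one place, so each change can now be read alone. Turning phenylsulfonyl into (4-nitrophenyl)sulfonyl gives a 1.8-fold higher number from compound 2 to compound 3 (0.25 log units; within the scatter) in this assay, and with nitro kept, trifluoromethyl in place of fluoro gives a 1.2-fold lower number from compound 1 to compound 3 (0.08 log units; within the scatter) in the same test, so neither change stands out from the scatter. Going by these compounds, whether an amine or a carboxylic acid in place of nitro on that ring would behave the same remains open. Nothing measured here explains these results.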